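Swapping the oxazole for a thiazole on the amide nitrogen

The compounds below may be only part of what the source reports. "The series", "measured", "known", "first", "only" and "open" are said of these compounds alone.

Three compounds share a core that links a phenyl-bearing triazole through an acetamide to a small heteroaryl group. In a functional assay on BMDM cells (Mus musculus, strain C57BL/6) for inhibition, with a stated time of 2 days (a higher number here means a weaker inhibitor, a lower number a stronger inhibitor), compound 1 `COc1ccc(-c2cn(CC(=O)Nc3nc(C)cs3)nn2)cc1` gives 3890 nM, compound 2 `O=C(Cn1cc(-c2ccc([N+](=O)[O-])cc2)nn1)Nc1nc2ccccc2s1` gives 3280 nM, and compound 3 `Cc1cc(NC(=O)Cn2cc(-c3ccc([N+](=O)[O-])cc3)nn2)no1` gives 1220 nM, the lowest number of the three. Among the measured compounds shown here, the one measured change at the amide nitrogen, a 2.7-fold lower number from compound 2 to compound 3 (0.43 log units; beyond the scatter), was modest. Compound 4 `Cc1csc(NC(=O)Cn2cc(-c3ccc([N+](=O)[O-])cc3)nn2)n1` alters compound 3 in the same place: 4-methyl-1,3-thiazol-2-yl in place of 5-methyl-1,2-oxazol-3-yl on an amide-type nitrogen. Compound 1 carries this same thiazole group, though with a different phenyl substituent, and its value in this assay sits higher than that of compound 3. A somewhat weaker result is therefore expected, with a 2.0-fold higher number from compound 3 to compound 4 (0.31 log units; beyond the scatter). Compound 4 is estimated at 2500 nM, with a likely range of 900 nM to 6500 nM.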

Compound 4, half-maximal inhibitory concentration: 190 nM
The estimate for compound 4 lay 13-fold (1.12 log units) above the measured number; the whole stated range lies above it.
By their numbers in this assay, from the lowest: compound 4; then compound 3; then compounds 2 and 1 (each within the scatter of the next).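

With the nitro group kept, the group on the amide-type nitrogen matters more than the earlier step suggested: 4-methyl-1,3-thiazol-2-yl gives a 6.4-fold lower number from compound 3 to compound 4 (0.81 log units; beyond the scatter) and a 17-fold lower number from compound 2 to compound 4 (1.24 log units; beyond the scatter). With that thiazole kept, nitro in place of methoxy on an aromatic carbon gives a 20-fold lower number from compound 1 to compound 4 (1.31 log units; beyond the scatter), so the thiazole alone does not carry the gain. Nothing available explains either change. Still open, as far as these compounds go, is how an amine or a nitrile in place of the nitro group would fare with this thiazole, and whether a longer chain on the thiazole would hold the gain.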